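A few compounds are considered here, and "the series" means these few. Any claim that something is new, unique, unknown or untested is made for them only; others in the source may bear on it.

The shared core of compound 1 `Cn1ncc(Cl)c1-c1cc(C(=O)NC2CNCCC2c2ccc(C(F)(F)F)cc2)oc1Cl` carries an amide to a saturated ring bearing a trifluoromethyl-substituted phenyl, and in an assay for inhibition of RAC-alpha serine/threonine-protein kinase (Homo sapiens), read by HTRF, with a stated time of 1 h (a lower number here means a stronger inhibitor, a higher number a weaker inhibitor), compound 1 gives 7.2 nM. Compound 2 `Cn1ncc(Cl)c1-c1cc(C(=O)N[C@@H]2CNCC[C@H]2c2ccc(C(F)(F)F)cc2)oc1Cl` has the same atoms and bonds, with both stereocentres at saturated ring carbons drawn S, and in this assay compound 2 gives 9.3 nM. The step of a 1.3-fold higher number from compound 1 to compound 2 (0.11 log units; within the scatter) is small, and the two compounds differ only in that one is drawn with a defined configuration and the other without, as noted in the fact that one of compounds 1 and 2 is drawn with a defined configuration and the other without, at the place where they differ. Compound 3 `O=C(N[C@@H]1CNCC[C@H]1c1ccc(Cl)cc1)c1ccc(-c2ncnc3c2CCC3O)s1`, built on a different core, reaches only a limit of the assay, as its value in this assay is > 1000 nM; this limit is what the limit of > 1000 nM in this assay, at which 1 of the 3 values shown sits, refers to. Among the numbers shown, compound 2 stands highest of the two that are numbers, with compound 1 nearest.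

Compound 4 `Cn1ncc(Cl)c1-c1cc(C(=O)N[C@H]2CNCC[C@@H]2c2ccc(C(F)(F)F)cc2)oc1Cl` is the mirror image of compound 2: the two compounds have the same atoms and bonds and differ only in configuration as drawn: 2 of 2 stereo elements differ (all stereocentres are inverted: mirror images); a stereocentre at a saturated ring carbon is drawn S in compound 2 and R in compound 4; a stereocentre at a saturated ring carbon is drawn S in compound 2 and R in compound 4. Among the compounds with values here, no measured step compares two fully drawn mirror images, so the only guide is the small step from compound 1 to compound 2. Compound 4 is therefore expected to differ from compound 2 by a 1.6-fold higher number from compound 2 to compound 4 (0.21 log units; within the scatter), with a wide range allowed in either direction. The estimate for compound 4 in this assay is 15 nM, between 3 nM and 150 nM.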

Compound 4, half-maximal inhibitory concentration: 127 nM
For compound 4 the middle estimate is 8.5-fold (0.93 log units) below the measured one; the range from low to high includes it.
By their numbers in this assay, from the lowest: compounds 1 and 2 (each within the scatter of the next); then compound 4. At a limit, above all of these: compound 3.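

Inverting both stereocentres at the saturated ring carbons, with no atom or bond changed, gives a 14-fold higher number from compound 2 to compound 4 (1.14 log units; beyond the scatter) in this assay, so the configuration at these two carbons matters in a way the earlier compounds could not show: the fact that compounds 2 and 4 differ only in the configuration as drawn

The step of an 18-fold higher number from compound 1 to compound 4 (1.25 log units; beyond the scatter) is also large, whereas the step of a 1.3-fold higher number from compound 1 to compound 2 (0.11 log units; within the scatter) is within the scatter, so the compound drawn without a configuration reads like the form drawn S at both carbons and not like the form drawn R at both: the fact that one of compounds 1 and 4 is drawn with a defined configuration and the other without, at the place where they differ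

Within the data shown here, this mirror-image pair gives the first step beyond the scatter among the compounds that share this core.

The compounds shown leave open how much each stereocentre contributes on its own, as both change together in this pair, and whether compound 1 is a single form or a mixture. They also leave open whether a step of this size would persist with another group, such as a nitrile or a methoxy group, in place of the trifluoromethyl on the phenyl.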